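The compounds below may be only part of what the source reports. "The series", "measured", "known", "first", "only" and "open" are said of these compounds alone.

Compound 2 `CCCn1c(=O)[nH]c2nc(-c3ccc(S(=O)(=O)N4CCN(C(C)c5ccccc5)CC4)cc3)[nH]c2c1=O` gives 0% in an assay on CHO cells for displacement of a labelled ligand from adenosine receptor A3 (Homo sapiens), read by scintillation counting, with a stated time of 45 min, tested at 1 uM, in the presence of a further agent that is not named here (a lower number here means less inhibition, a higher number more inhibition at the concentration tested (going by the name of the read-out)), and compound 1 `CCCn1c(=O)[nH]c2nc(-c3ccc(S(=O)(=O)N4CCN(c5ccccc5F)CC4)cc3)[nH]c2c1=O` gives 9%, so the two readings sit close together: a number 9 percentage points lower from compound 1 to compound 2 (within the scatter) lies within the scatter. Compound 3 `CCCn1c(=O)[nH]c2nc(-c3ccc(S(=O)(=O)N4CCN(c5ccccc5)CC4)cc3)[nH]c2c1=O` differs from compound 2 by phenyl in place of 1-phenylethyl on an amine nitrogen in a ring. Going by the values given here, only one measured step bears on this change; it too exchanged the group on that ring nitrogen, and it moved the reading only within the scatter. The step of a number 5 percentage points higher from compound 2 to compound 3 (within the scatter) is therefore expected to stay within the scatter as well. Compound 3 is estimated at 5%, with a range from 0% to 20%.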

Compound 3, a percentage reported as inhibition, at one concentration (the size of the read-out at that concentration, not a potency): 27%
Beside the measured number, compound 3's estimate is 22 percentage points below it; the measured number lies above the stated range.
By their numbers in this assay, from the lowest: compounds 2 and 1 (each within the scatter of the next); then compound 3.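

In this assay the group on the ring nitrogen can clearly move the reading: phenyl in place of 1-phenylethyl gives a number 27 percentage points higher from compound 2 to compound 3 (beyond the scatter) and hydrogen in place of fluoro on an aromatic carbon gives a number 18 percentage points higher from compound 1 to compound 3 (beyond the scatter) while the earlier exchange stayed within the scatter. Phenyl thus stands apart from both 1-phenylethyl and 2-fluorophenyl, and the loss of a single fluoro is enough to separate two compounds.

As far as these compounds go, whether a benzyl group, a longer chain or a chloro on that phenyl would keep or raise the reading remains open. Nothing shown here gives a reason for these steps.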